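The source may hold more compounds than are shown below. What is called first, only, known or untested is meant among the compounds shown, and "the series" means these compounds.

Working notes on the series. Compound 1 `C=C(C)[C@@H]1CC=C(Cn2cc(COc3ccc(C4NC(=O)NC(C)=C4C(C)=O)cc3)nn2)CC1` serves as the reference point; in a functional assay on UACC-62 cells (Homo sapiens) for inhibition, read by sulforhodamine B assay, with a stated time of 48 h (on this read-out higher numbers stand for weaker inhibition of growth and lower numbers for stronger inhibition of growth), compound 1 gives 20500 nM. Compound 2 `C=C(C)[C@@H]1CC=C(Cn2cc(COc3cccc(C4NC(=O)NC(C)=C4C(C)=O)c3)nn2)CC1` has the same atoms joined differently, and the difference between the two cores is not broken down here. In this assay compound 2 gives 31600 nM, within the scatter of compound 1. Compound 3 `C=C(C)[C@@H]1CC=C(Cn2cc(COc3cc(C4NC(=O)NC(C)=C4C(C)=O)ccc3OC)nn2)CC1` sits at the limit of > 100000 nM in this assay, at which 1 of the 3 values shown sits. In this assay compound 3 gives > 100000 nM, which is a limit and not a number. The step of an at least 3.1-fold higher number from compound 2 to compound 3 (0.50 log units; beyond the scatter) goes with the change (methoxy in place of hydrogen on an aromatic carbon). Compound 4 `C=C(C)[C@@H]1CC=C(Cn2cc(COc3ccc(C4NC(=O)NC(C)=C4C(C)=O)cc3OC)nn2)CC1` differs from compound 1 by the same kind of change, (methoxy in place of hydrogen on an aromatic carbon), the methoxy now meta to a large group rather than para to a large group. Among the measured compounds shown here, the step of a 2.9-fold higher number from compound 1 to compound 4 (0.47 log units; beyond the scatter) is expected to resemble an at least 3.1-fold higher number from compound 2 to compound 3 (0.50 log units; beyond the scatter), the one measured instance of this change. Compound 4 is therefore expected to give roughly 60000 nM in this assay.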

Compound 4, concentration for total growth inhibition: 3830 nM
Compound 4: the middle estimate sits 16-fold (1.19 log units) above what was measured; measured number below the stated range.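

In this assay, methoxy in place of hydrogen on an aromatic carbon gives a 5.4-fold lower number from compound 1 to compound 4 (0.73 log units; beyond the scatter), and the change does not carry over from one core to the other: the same change on two cores in this assay, an at least 3.1-fold higher number (0.50 log units; beyond the scatter) from compound 2 to compound 3 and a 5.4-fold lower number (0.73 log units; beyond the scatter) from compound 1 to compound 4, at least 16-fold (1.22 log units) apart, beyond the scatter of two such steps. Compound 3 gives > 100000 nM, which is a limit and not a number. The result shows that the step measured on one core cannot be read across to the other in this series, but it does not show why the two cores part, and one pair per core gives no general rule for either.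

Left open is whether ethoxy, hydroxy or an amine in place of the methoxy would follow compound 3 or compound 4. Also open, from the compounds shown here alone, is whether any such group would give the same step on both cores.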